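The source may hold more compounds than are shown below. What is called first, only, known or untested is meant among the compounds shown, and "the series" means these compounds.

Compound 1 `COc1cc2c(Oc3ccc(NC(=O)c4nn(-c5ccccc5OC(F)(F)F)c(=O)cc4C)cc3F)ccnc2cc1OCCCN1CCC(C)CC1` and compound 2 `COc1cc2c(Oc3ccc(NC(=O)c4nn(-c5ccccc5OC(F)(F)F)c(=O)cc4C)cc3F)ccnc2cc1OCCCN1CCN(C)CC1` share one core. In a functional assay on A549 cells (Homo sapiens) for inhibition, read by MTT assay, with a stated time of 72 h (on this read-out higher numbers stand for weaker inhibition and lower numbers for stronger inhibition), compound 1 gives 90 nM and compound 2 gives 130 nM, which amounts to a 1.4-fold higher number from compound 1 to compound 2 (0.16 log units; within the scatter). The change between them is 4-methylpiperazin-1-yl in place of 4-methylpiperidin-1-yl on a saturated chain carbon, three bonds along the chain from an oxygen on an aromatic ring. Compound 3 `COc1ccc(-n2nc(C(=O)Nc3ccc(Oc4ccnc5cc(OCCCN6CCC(C)CC6)c(OC)cc45)c(F)c3)c(C)cc2=O)cc1` carries a different core: it differs from compound 1 by 4-methoxyphenyl in place of 2-(trifluoromethoxy)phenyl on an aromatic nitrogen. In this assay compound 3 gives 1100 nM, which amounts to a 12-fold higher number from compound 1 to compound 3 (1.09 log units; beyond the scatter). Compound 4 `COc1ccc(-n2nc(C(=O)Nc3ccc(Oc4ccnc5cc(OCCCN6CCN(C)CC6)c(OC)cc45)c(F)c3)c(C)cc2=O)cc1` has not yet been measured. It differs from compound 3 by 4-methylpiperazin-1-yl in place of 4-methylpiperidin-1-yl on a saturated chain carbon, three bonds along the chain from an oxygen on an aromatic ring, the same change that separates the first pair, made at the same place. Because the first pair shows a 1.4-fold higher number from compound 1 to compound 2 (0.16 log units; within the scatter), the step from compound 3 to compound 4 is expected to be a 1.4-fold higher number from compound 3 to compound 4 (0.13 log units; within the scatter). Compound 4 is therefore estimated at 1500 nM in this assay. The expected range for compound 4 runs from 700 nM to 3200 nM.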

Compound 4, half-maximal inhibitory concentration: 2200 nM
Compound 4: the middle estimate sits 1.5-fold (0.17 log units) below what was measured; the range from low to high includes it.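

In this assay, 4-methylpiperazin-1-yl in place of 4-methylpiperidin-1-yl gives a 2.0-fold higher number from compound 3 to compound 4 (0.30 log units; within the scatter), and this step carries over from one core to the other with little change in size: the same change on two cores in this assay, a 1.4-fold higher number (0.16 log units; within the scatter) from compound 1 to compound 2 and a 2.0-fold higher number (0.30 log units; within the scatter) from compound 3 to compound 4, 1.4-fold (0.14 log units) apart, within the scatter of two such steps. Likewise, 4-methoxyphenyl in place of 2-(trifluoromethoxy)phenyl on an aromatic nitrogen gives a 17-fold higher number from compound 2 to compound 4 (1.23 log units; beyond the scatter), about the same large step with either end group on the chain: the same change on two cores in this assay, a 12-fold higher number (1.09 log units; beyond the scatter) from compound 1 to compound 3 and a 17-fold higher number (1.23 log units; beyond the scatter) from compound 2 to compound 4, 1.4-fold (0.14 log units) apart, within the scatter of two such steps. These results show that the two changes combined without visible interference in these four compounds in this one assay, but they do not show that either change would carry to other cores or other read-outs.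

The compounds shown leave open whether this holds with a morpholine at the end of the chain or with a longer chain. They also leave open how a plain phenyl on the aromatic nitrogen would compare.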